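The source may report more compounds than this note shows. Statements on the series, on what has been measured and on what is new or still open speak of the compounds shown alone.

Measured so far in a functional assay on SW-620 cells (Homo sapiens) for cytotoxicity, read by MTT assay, with a stated time of 48 h; on this read-out lower numbers stand for stronger inhibition and higher numbers for weaker inhibition:
compound 1 `CCCCCCCCNC(=O)[C@@H](NC(=O)/C=C/c1ccccc1)[C@@H](C)O` gives 61400 nM;
compound 2 `C/C=C/C=C/C(=O)N[C@H](C(=O)NCCCCCCCC)[C@@H](C)O` gives 200000 nM;
compound 3 `CCCCCCCCCCCCCCNC(=O)[C@@H](NC(=O)/C=C/c1ccccc1)[C@@H](C)O` gives 200000 nM.

Compound 2 and compound 3 stand together at the highest of the three numbers, within the scatter of each other. The change from compound 1 to compound 2, (prop-1-en-1-yl in place of phenyl on a double-bonded chain carbon bound to a double-bonded chain carbon), made a 3.3-fold higher number from compound 1 to compound 2 (0.51 log units; beyond the scatter). The cores of compound 1 and compound 3 differ by hexyl in place of hydrogen on a saturated chain carbon, eight bonds along the chain from an amide-type nitrogen, which made a 3.3-fold higher number from compound 1 to compound 3 (0.51 log units; beyond the scatter). Compound 4 `C/C=C/C=C/C(=O)N[C@H](C(=O)NCCCCCCCCCCCCCC)[C@@H](C)O` is not yet measured; it carries the same change on the core of compound 3, (prop-1-en-1-yl in place of phenyl on a double-bonded chain carbon bound to a double-bonded chain carbon).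

From compound 3 to compound 4 the expected step in this assay is a 1.3-fold higher number from compound 3 to compound 4 (0.10 log units; within the scatter), near the earlier one, resting on compound 1 because of a 3.3-fold higher number from compound 1 to compound 2 (0.51 log units; beyond the scatter). Compound 4 is estimated at 250000 nM, between 120000 nM and 600000 nM; a limit rather than a number is plausible.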

Compound 4, half-maximal inhibitory concentration: 200000 nM
Beside the measured number, compound 4's estimate is 1.3-fold (0.10 log units) above it; the measured number falls inside the stated range.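

In this assay, prop-1-en-1-yl in place of phenyl does not carry over unchanged from the core of compound 1 to the core of compound 3, giving no change at the digits printed from compound 3 to compound 4 (within the scatter): the same change on two cores in this assay, a 3.3-fold higher number (0.51 log units; beyond the scatter) from compound 1 to compound 2 and no change at the digits printed (within the scatter) from compound 3 to compound 4, 3.3-fold (0.51 log units) apart, beyond the scatter of two such steps

The hexyl addition likewise gives a different result on the second core, with no change at the digits printed from compound 2 to compound 4 (within the scatter): the same change on two cores in this assay, a 3.3-fold higher number (0.51 log units; beyond the scatter) from compound 1 to compound 3 and no change at the digits printed (within the scatter) from compound 2 to compound 4, 3.3-fold (0.51 log units) apart, beyond the scatter of two such steps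

This single set of four compounds shows that neither step transfers as a constant amount here, but it does not show how either change would behave on any other core.

Open, as far as these compounds go, is how a decyl chain on the amide nitrogen, or an amine or a carboxylic acid in place of phenyl, would read in this assay.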